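Replacing pyrazin-2-yl with 5-methyl-1H-pyrazol-3-yl

This account rests on a few compounds, and the source may have more. Where it says the series, first, only, none or still open, it means among the compounds named here.

Measured so far in a physicochemical assay for solubility, measured as kinetic solubility; on this read-out lower numbers stand for lower solubility and higher numbers for higher solubility (two compounds)
Compound 1 `COc1ccc(-c2nn3c(-c4cccs4)nnc3s2)cc1OC` gives 3000 nM (the lower number)
Compound 2 `c1csc(-c2nnc3sc(-c4cnccn4)nn23)c1` gives 30000 nM (the higher number)

Compound 2 stands highest of these two numbers. The gap from compound 2 to compound 1 lies beyond the usual scatter of repeated measurements. The next molecule, compound 3 `Cc1cc(-c2nn3c(-c4cccs4)nnc3s2)n[nH]1`, keeps the shared core of compound 2 but carries 5-methyl-1H-pyrazol-3-yl in place of pyrazin-2-yl on an aromatic carbon. Within the data shown here, no measured pair shows this swap, so any forecast is rough. With compound 2 at the top at 30000 nM and compound 1 lower at 3000 nM, a fall seems more likely than a rise. The expected change is a modest fall, estimated as a 3.0-fold lower number from compound 2 to compound 3 (0.48 log units; beyond the scatter) (just beyond the scatter). In this assay compound 3 is estimated to give 10000 nM (expected range from 3000 nM to 30000 nM).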

Compound 3, solubility: 58000 nM
For compound 3 the middle estimate is 5.8-fold (0.76 log units) below the measured one; the measured number lies above the stated range.
By their numbers in this assay, from the lowest: compound 1; then compounds 2 and 3 (each within the scatter of the next).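

In this assay, the position on the five-membered aromatic ring of the shared core accepts 5-methyl-1H-pyrazol-3-yl in place of pyrazin-2-yl with a 1.9-fold higher number from compound 2 to compound 3 (0.29 log units; within the scatter), so the two groups cannot be told apart on this read-out. The swap replaces a six-membered aromatic ring with a five-membered one and brings in a hydrogen-bond donor where the leaving group has none, yet the two numbers remain within the scatter of each other. Nothing measured here offers an explanation for this result.

As far as these compounds go, it remains open whether plain 1H-pyrazol-3-yl, without the methyl, would give a similar number. The compounds shown also leave open how an amine or a carboxylic acid on this ring position would read out, and whether this single pair holds with other groups in place of the thiophene.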